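Replacing a Ring Substituent on a Toll-like Receptor 8 Agonist Scaffold

The compounds below may be only part of what the source reports. "The series", "measured", "known", "first", "only" and "open" are said of these compounds alone.

Of the compounds shown here, two sharing one core have been tested in an ADME assay on HEK293 cells for agonist activity at Toll-like receptor 8 (Homo sapiens), read by a luciferase reporter, with a stated time of 6 h; on this read-out lower numbers stand for an effect already at smaller amounts and higher numbers for an effect only at larger amounts of compound. Compound 1 `CCCCNc1nc(N)nc2ccc(C(C)=O)cc12` carries an acetyl group on its aromatic ring and in this assay compound 1 gives 1.9 uM. Compound 2 `CCCCNc1nc(N)nc2cccc(CC3CCCC3)c12` instead carries a cyclopentylmethyl group. For compound 2 in this assay only a limit was reported, > 25 uM, so no number is known for it; it sits at the limit of > 25 uM in this assay, at which 1 of the 2 values shown sits. For the measured compounds named here, no step between two measured compounds can therefore be counted here, and the two values show only that compound 1 has a number while compound 2 does not.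

Compound 3 `CCCCNc1nc(N)nc2cccc(C(=O)NC)c12` has not yet been measured. It differs from compound 2 in one place: methylcarbamoyl in place of cyclopentylmethyl on an aromatic carbon. Since compound 2 stands at a limit, the size of the step to compound 3 cannot be anchored; the expectation is that compound 3 moves toward smaller effective amounts, by an at least 3.1-fold lower number from compound 2 to compound 3 (0.49 log units; beyond the scatter), though this remains a guess. In this assay compound 3 is estimated at 8 uM, with a plausible range from 1.5 uM to 25 uM.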

Compound 3, minimum effective concentration: 0.39 uM
Compound 3: middle estimate off by 21-fold (1.31 log units), on the high side; measured number below the stated range.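

On this aromatic carbon, ortho to a fused ring, the choice of group makes a large difference: in this assay, methylcarbamoyl in place of cyclopentylmethyl gives an at least 64-fold lower number from compound 2 to compound 3 (1.80 log units; beyond the scatter), a change well beyond the scatter. For the compounds shown here, the first two compounds offered no step to read, so this is the first single-place change that can be sized, and it shows that this position can carry a group while the compound still acts at small amounts. The step gives only a minimum size, and its true size stays unknown, since compound 2 has a limit and not a number: the limit of > 25 uM in this assay, at which 1 of the 3 values shown sits.

The change swaps several things at once, removing a five-membered carbon ring and bringing in a carbonyl, a hydrogen-bond donor and a hydrogen-bond acceptor on a smaller group, and the compounds shown do not separate these features from one another. From the compounds shown here alone, how a carboxylic acid, a methyl ester or a plain ethyl chain on this same carbon would read remains open, and any of these could help show which feature of methylcarbamoyl goes with the lower number.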